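The compounds below may be only part of what the source reports. "The series", "measured", "known", "first", "only" and "open" are said of these compounds alone.

Of the compounds shown here, three built on one shared core have been tested in an assay on Sf9 cells for inhibition of protein deacetylase HDAC6 (Homo sapiens), read by fluorescence, with a stated time of 40 min, tested at 100 nM; a higher number here means more inhibition at the concentration tested (going by the name of the read-out), a lower number less inhibition. Compound 1 `COc1ccc(-n2nc(-c3ccccc3)nc2CNc2ccc(C(=O)NO)cc2)cc1` gives 63.4%. Compound 2 `O=C(NO)c1ccc(NCc2nc(-c3ccco3)nn2-c2ccccc2)cc1` gives 59.9%, and compound 3 `COc1ccc(-n2nc(-c3ccc(O)cc3)nc2CNc2ccc(C(=O)NO)cc2)cc1` gives 70.3%. On these numbers compound 1 stands second highest of the three, yet both other values lie within the usual scatter of it, so no real ordering can be read from them. Among the measured compounds shown here, the only step between compounds that differ in a single place, a number 6.9 percentage points higher from compound 1 to compound 3 (within the scatter), is likewise within the scatter.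

Compound 4 `O=C(NO)c1ccc(NCc2nc(-c3ccccc3)nn2-c2ccc(C(F)(F)F)cc2)cc1` differs from compound 1 in one place: trifluoromethyl in place of methoxy on an aromatic carbon. For the measured compounds named here, no measured pair swaps these two groups, so none of the measured steps bears directly on this change; the one single-point step available concerns a different group elsewhere on the core and stayed within the scatter. The expectation is therefore a step of no size beyond the scatter, and compound 4 is expected to shift by a number 3.4 percentage points lower from compound 1 to compound 4 (within the scatter). Compound 4 is estimated at 60%, within a range from 40% to 80%.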

Compound 4, a percentage reported as inhibition, at one concentration (the size of the read-out at that concentration, not a potency): 38.9%
The estimate for compound 4 lay 21.1 percentage points above the measured number; measured number outside the range, below it.
By their numbers in this assay, from the lowest: compound 4; then compounds 2, 1 and 3 (each within the scatter of the next, the first and the last beyond it).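

In this assay, among the compounds shown here, the place on the six-membered aromatic ring that carries methoxy in compound 1 proves sensitive to change: trifluoromethyl in place of methoxy gives a number 24.5 percentage points lower from compound 1 to compound 4 (beyond the scatter) as the first step in this set to lie beyond the scatter. The earlier one-place step, a number 6.9 percentage points higher from compound 1 to compound 3 (within the scatter) and concerning hydroxy elsewhere on the shared core, gave no such sign. Nothing available here explains what lies behind the new step.

Going by these compounds, with only these two groups compared at this place, it remains open whether the step reflects the departure of methoxy or the arrival of trifluoromethyl. Plain hydrogen, an amine or a carboxylic acid at the same place would help separate the two and show how widely the number can move there.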